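This account rests on a few compounds, and the source may have more. Where it says the series, first, only, none or still open, it means among the compounds named here.

Working notes on the series. Of the compounds shown here, two have numbers so far. Compound 1 `CCC(CC)(c1nnc[nH]1)c1ccc(-c2ccc3cc(F)cc(F)c3c2)[nH]c1=O` in a functional assay on CHO cells for antagonist activity at prostaglandin E2 receptor EP3 subtype (Homo sapiens), read by cAMP accumulation (on this read-out higher numbers stand for weaker inhibition and lower numbers for stronger inhibition), gives 350 nM. Compound 2 `CC(C)C(c1ncco1)c1ccc(-c2ccc3cccc(F)c3c2)[nH]c1=O` in this assay gives 64 nM, the lower of the two numbers; its nearest neighbour is compound 1, and the gap between the two lies beyond the scatter. For the measured compounds named here, the two differ in several places at once, so no single step between them can be read off.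

The next compound to be run is compound 3 `CC(C)C(Cc1noc(=O)[nH]1)c1ccc(-c2ccc3cccc(F)c3c2)[nH]c1=O`. It differs from compound 2 in one place: a group of 7 heavy atoms (3 carbon, 2 nitrogen, 2 oxygen; one five-membered aromatic ring with 3 hetero atoms) in place of a group of 5 heavy atoms (3 carbon, 1 nitrogen, 1 oxygen; one five-membered aromatic ring with 2 hetero atoms), on a saturated chain carbon bound to an aromatic carbon and a saturated chain carbon. Going by the values given here, no measured pair carries this exchange, so the direction of the step is not backed by data. The working expectation is a step in this assay toward a somewhat higher number, of a size not far beyond the scatter. For compound 3 the estimate in this assay is 150 nM, with a range from 30 nM to 700 nM, meaning an expected step of a 2.3-fold higher number from compound 2 to compound 3 (0.37 log units; beyond the scatter).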

Compound 3, half-maximal inhibitory concentration: 70 nM
Estimate against measurement, compound 3: 2.1-fold (0.33 log units) above; low and high end bracket the measured number.
By their numbers in this assay, from the lowest: compounds 2 and 3 (each within the scatter of the next); then compound 1.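

For the compounds shown here, at the saturated chain carbon bound to an aromatic carbon and a saturated chain carbon, replacing the 1,3-oxazol-2-yl group with the group of 7 heavy atoms gives, in this assay, the first single-place step: a 1.1-fold higher number from compound 2 to compound 3 (0.04 log units; within the scatter). At this position, then, the read-out stays within the scatter despite the exchange of one five-membered aromatic ring for another, with more heavy atoms and a hydrogen-bond donor entering. No measurement of any property of these two groups bears on this result.

This single pair cannot show whether the hydrogen-bond donor in the entering group matters, and a methyl group on that ring nitrogen would address this. As far as these compounds go, how a carboxylic acid or an amine on the same carbon would read in this assay also stays open.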